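A few compounds are considered here, and "the series" means these few. Any claim that something is new, unique, unknown or untested is made for them only; others in the source may bear on it.

Notes on the series. Compound 1 `O=C1/C(=C/c2ccc(F)cc2)CN(S(=O)(=O)c2ccc(Cl)cc2)C/C1=C\c1ccc(F)cc1` gives 4500 nM in a functional assay on HepG2 cells (Homo sapiens) for cytotoxicity, read by MTT assay, with a stated time of 24 h; a higher number here means a weaker inhibitor, a lower number a stronger inhibitor. Among the measured compounds shown here, compound 2 `N#Cc1ccc(S(=O)(=O)N2C/C(=C\c3ccc(F)cc3)C(=O)/C(=C/c3ccc(F)cc3)C2)cc1` gives 9800 nM in this assay, the highest of the two numbers so far; the only known step, a 2.2-fold higher number from compound 1 to compound 2 (0.34 log units; beyond the scatter), is modest. Compound 3 `CC(=O)Nc1ccc(S(=O)(=O)N2C/C(=C\c3ccc(F)cc3)C(=O)/C(=C/c3ccc(F)cc3)C2)cc1` is not yet measured; it carries acetamido in place of cyano on an aromatic carbon. For the measured compounds named here, no measured step exchanges cyano for acetamido, so the step from compound 1 to compound 2 bears on it only loosely. The expected step in this assay is a 1.2-fold higher number from compound 2 to compound 3 (0.09 log units; within the scatter), a small move toward a higher number. The estimate for compound 3 in this assay is 12000 nM, expected between 5000 nM and 30000 nM.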

Compound 3, half-maximal inhibitory concentration: 7400 nM
Beside the measured number, compound 3's estimate is 1.6-fold (0.21 log units) above it, and the stated range covers the measured number.
By their numbers in this assay, from the lowest: compounds 1, 3 and 2 (each within the scatter of the next, the first and the last beyond it).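

In this assay, acetamido on this aromatic carbon, para to a large group, gives a 1.3-fold lower number from compound 2 to compound 3 (0.12 log units; within the scatter) and a 1.6-fold higher number from compound 1 to compound 3 (0.22 log units; within the scatter). Acetamido brings a hydrogen-bond donor that cyano lacks, yet neither step leaves the scatter, so compound 3 cannot be placed apart from compound 1 or compound 2. Nothing available explains these steps. Open, on these data alone, is whether an amine or a carboxylic acid at this position would give a step beyond the scatter. Also open, as far as these compounds go, is whether a longer acyl chain in place of acetamido would do so.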